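Trimming the amide nitrogen from phenyl to methyl

A few compounds are considered here, and "the series" means these few. Any claim that something is new, unique, unknown or untested is made for them only; others in the source may bear on it.

Compound 3 `CCN(Cc1ccccc1)Cc1ccccc1C(=O)N(C)c1ccccc1` stands only at the edge of the numbers: in an assay on brain with Translocator protein (Rattus norvegicus) as the target (a lower number here means a stronger inhibitor, a higher number a weaker inhibitor), compound 3 gives > 10000 nM, which is a limit of the assay and not a number. Compound 1 `CCN(Cc1ccccc1)Cc1ccccc1C(=O)N(CC)CC` gives 8210 nM in this assay, and the change to its amide gave an at least 1.2-fold higher number from compound 1 to compound 3 (0.08 log units; that floor lies within the scatter). Compound 2 `CCN(Cc1ccccc1)Cc1nc2ccccc2c(-c2ccccc2)c1C(=O)NCc1ccccc1`, built on a different core, gives 2900 nM. Compound 4 `CCN(Cc1ccccc1)Cc1ccccc1C(=O)N(C)C` carries methyl in place of phenyl on an amide-type nitrogen. For the measured compounds named here, the one measured step at this nitrogen was the small one from compound 1 to compound 3, so compound 4, which resembles compound 1 more closely, is expected to sit near that level, with a step of an at least 1.1-fold lower number from compound 3 to compound 4 (0.04 log units; that floor lies within the scatter) in this assay. For compound 4 the expected value is 9000 nM, in the range 3000 nM to 30000 nM.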

Compound 4, half-maximal inhibitory concentration: > 10000 nM
Compound 4 was reported as a limit; the forecaster's own chance of this, stated with the estimate: 40%; at least 1.1-fold (0.04 log units) between middle value and limit.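

In this assay, removing the phenyl in favour of methyl on the amide-type nitrogen does not bring a measured value into view: compound 4, like compound 3, is reported only as a limit. Dimethylamino in place of diethylamino on the carbonyl carbon gives an at least 1.2-fold higher number from compound 1 to compound 4 (0.08 log units; that floor lies within the scatter), and this is only a floor for the step. The step from compound 3 to compound 4 cannot be read, because both compounds are reported at the same limit: the limit of > 10000 nM in this assay, at which 2 of the 4 values shown sit.

As far as these compounds go, whether compound 3 and compound 4 truly differ remains open. So does how dipropylamino on the carbonyl carbon of the shared core would read.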